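The compounds below may be only part of what the source reports. "The series", "measured", "known", "first", "only" and "open" are said of these compounds alone.

Working notes on the series. Compound 1 `FC(F)(F)c1ccc(COc2cccc(Nc3ncnc4cc5c(cc34)OCCOCCOCCO5)c2)cc1` carries the larger core; in a functional assay on MCF7 cells (Homo sapiens) for antiproliferative activity, read by MTT assay, with a stated time of 72 h (a higher number here means a weaker inhibitor, a lower number a stronger inhibitor), compound 1 gives 17600 nM. Compound 3 `FC(F)(F)c1ccc(COc2ccc(Nc3ncnc4cc5c(cc34)OCCOCCO5)cc2)cc1` has the smaller core, and in this assay compound 3 returns only a limit of the assay, > 100000 nM. Compound 2 `c1ccc(COc2ccc(Nc3ncnc4cc5c(cc34)OCCOCCO5)cc2)cc1` also returns only a limit in this assay, > 100000 nM. How the two cores of compound 1 and compound 3 differ is not broken down here. From compound 3 to compound 2 the change is hydrogen in place of trifluoromethyl on an aromatic carbon; its size is a step that the two limits leave unreadable from compound 3 to compound 2, unreadable because of the limit of > 100000 nM in this assay, at which 2 of the 3 values shown sit. Compound 4 `c1ccc(COc2cccc(Nc3ncnc4cc5c(cc34)OCCOCCOCCO5)c2)cc1` is still to be measured and differs from compound 1 by hydrogen in place of trifluoromethyl on an aromatic carbon, the same change. For compound 4 the expected step is a 2.0-fold higher number from compound 1 to compound 4 (0.30 log units; within the scatter). That expectation rests on compound 1 at 17600 nM alone, as the measured pair gives no size. Compound 4 is estimated at 35000 nM, between 12000 nM and 100000 nM.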

Compound 4, half-maximal inhibitory concentration: > 100000 nM
Compound 4 gave a limit, no number; the forecaster's own chance of this, stated with the estimate: 35%; at least 2.8-fold (0.45 log units) between middle value and limit.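

Among these compounds, on the core of compound 1, hydrogen in place of trifluoromethyl gives an at least 5.6-fold higher number from compound 1 to compound 4 (0.75 log units; beyond the scatter), so on this core the trifluoromethyl compound holds the only measured number. In this assay, from the compounds shown here alone, compound 4 returns only a limit of the assay, > 100000 nM, so the full size of that step stays unknown. The step from compound 3 to compound 2 cannot be read, so it remains undecided whether the change has a similar size on both cores, because of this: the limit of > 100000 nM in this assay, at which 3 of the 4 values shown sit.

The compounds shown leave open how other groups at this place on the benzyl ring, such as chlorine, methoxy, nitrile or an amine, would compare with trifluoromethyl on the core of compound 1. They also leave open whether a carboxylic acid there would give a readable number on either core.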